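Methoxy for Methyl on the Fused Core

A few compounds are considered here, and "the series" means these few. Any claim that something is new, unique, unknown or untested is made for them only; others in the source may bear on it.

Compound 1 `O=C(CCC(=O)c1ccccc1)Nc1nc2ccc(Cl)cc2s1` and compound 2 `Cc1ccc2nc(NC(=O)CCC(=O)c3ccccc3)sc2c1` share one core and were both tested in a functional assay on the whole organism with Mus musculus as the target, with a stated time of 0.5 h; a higher number here means that more compound is needed for the effect, a lower number that less compound is needed. Compound 1 gives 300 mg/kg, and compound 2 gives 300 mg/kg. The step of no change at the digits printed from compound 1 to compound 2 (within the scatter) shows that methyl in place of chloro on an aromatic carbon left the minimum effective dose unchanged within the scatter, so compound 2 stands level with compound 1. Compound 3 `COc1ccc2nc(NC(=O)CCC(=O)c3ccccc3)sc2c1` has not yet been measured. It differs from compound 2 by methoxy in place of methyl on an aromatic carbon. Going by the values given here, only one measured step bears on this change, the exchange on the same aromatic carbon, and that step was flat. A step of no change at the digits printed from compound 2 to compound 3 (within the scatter) is therefore expected in this assay, none beyond the scatter. Compound 3 is estimated to give 300 mg/kg, with a range from 150 mg/kg to 600 mg/kg.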

Compound 3, minimum effective dose: 100 mg/kg
The estimate for compound 3 lay 3.0-fold (0.48 log units) above the measured number; the whole stated range lies above it.
By their numbers in this assay, from the lowest: compound 3; then compounds 1 and 2 (each within the scatter of the next).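

At this aromatic carbon, the swap of chloro for methyl had left the dose unchanged within the scatter, so the position had shown no response to its substituent. In this assay methoxy gives the first response, with a 3.0-fold lower number from compound 2 to compound 3 (0.48 log units; beyond the scatter) and likewise a 3.0-fold lower number from compound 1 to compound 3 (0.48 log units; beyond the scatter) when set against chloro, so the position is not indifferent to what it carries. The methoxy brings an oxygen and a hydrogen-bond acceptor that the methyl lacks, but no measurement here explains the lower dose.

The compounds shown leave open whether the oxygen itself or the extra heavy atom matters, which a hydroxyl, an amine or an ethyl group on the same carbon could test. They also leave open whether a longer alkoxy chain, such as ethoxy, would lower the dose further or lose the step.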